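This account rests on a few compounds, and the source may have more. Where it says the series, first, only, none or still open, it means among the compounds named here.

Values in a functional assay on HCT-116 cells (Homo sapiens) for antiproliferative activity, read by MTT assay, with a stated time of 72 h; a higher number here means a weaker inhibitor, a lower number a stronger inhibitor:
- Compound 1 `COc1cccc(N2C(=O)COc3ccc(-c4cnc(Cl)c(NS(=O)(=O)c5ccc(F)cc5)c4)cc32)c1`: > 40000 nM (a limit)
- Compound 2 `CC(C)N1C(=O)COc2ccc(-c3cnc(Cl)c(NS(=O)(=O)c4ccc(F)cc4)c3)cc21`: 18900 nM
- Compound 3 `O=C1COc2ccc(-c3cnc(Cl)c(NS(=O)(=O)c4ccc(F)cc4)c3)cc2N1`: > 40000 nM (a limit)

Compound 2 alone has a true number in this assay. The other two compounds sit at the limit of > 40000 nM in this assay, at which 2 of the 3 values shown sit.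

Compound 4 `COc1ncc(-c2ccc3c(c2)N(C(C)C)C(=O)CO3)cc1NS(=O)(=O)c1ccc(F)cc1` differs from compound 2 in one place: methoxy in place of chloro on an aromatic carbon. The measured steps all change the group on the amide-type nitrogen instead: an at least 2.1-fold lower number from compound 1 to compound 2 (0.32 log units; beyond the scatter), an at least 2.1-fold higher number from compound 2 to compound 3 (0.32 log units; beyond the scatter) and a step that the two limits leave unreadable from compound 1 to compound 3. None of them tests methoxy in place of chloro, so the direction is uncertain, and the expectation stays anchored on compound 2 at 18900 nM. A modest change is the tentative expectation, namely a 2.4-fold lower number from compound 2 to compound 4 (0.37 log units; beyond the scatter). Compound 4 is estimated at 8000 nM, with an expected range of 1500 nM to 30000 nM.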

Compound 4, half-maximal inhibitory concentration: 19200 nM
Beside the measured number, compound 4's estimate is 2.4-fold (0.38 log units) below it; measured number inside the range.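

Putting methoxy in place of chloro on the aromatic carbon next to the ring nitrogen gives a 1.0-fold higher number from compound 2 to compound 4 (0.01 log units; within the scatter) in this assay, so the two groups stand level at this position. This is the first change shown away from the amide-type nitrogen, and the first step between two true numbers. Compound 1 and compound 3 each rest on a limit, not a number: the limit of > 40000 nM in this assay, at which 2 of the 4 values shown sit.

As far as these compounds go, whether an amine or a nitrile at this position would give a different number remains open. So does the effect of a longer chain, such as butoxy, in place of methoxy.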